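This account rests on a few compounds, and the source may have more. Where it says the series, first, only, none or still open, it means among the compounds named here.

Measured compounds in an ADME assay on PC-3 cells (Homo sapiens) for cytotoxicity, read by WST assay, tested at 100 uM; a higher number here means more inhibition at the concentration tested (going by the name of the read-out), a lower number less inhibition:

compound 1, `CSc1cccc(NC(=O)C2CCCN(C(=O)c3cc(C(F)(F)F)cc(C(F)(F)F)c3)C2)c1`: 0%
compound 2, `O=C(Nc1cccc(CN2CCCC2)c1)C1CCCN(C(=O)c2cc(C(F)(F)F)cc(C(F)(F)F)c2)C1`: 51%
compound 3, `C=CCOc1cccc(NC(=O)C2CCCN(C(=O)c3cc(C(F)(F)F)cc(C(F)(F)F)c3)C2)c1`: 0%

Compound 3 sits level with compound 1 in this assay, the two together the lowest of the three numbers; compound 2 stands apart, with a number 51 percentage points lower from compound 2 to compound 3 (beyond the scatter). The one large movement in the set, a number 51 percentage points higher from compound 1 to compound 2 (beyond the scatter), comes from a change on the aromatic ring of the amide substituent, whereas no change at the digits printed from compound 1 to compound 3 (within the scatter) leaves the read-out where it was.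

The next compound is compound 4, `O=C(Nc1ccc(Cl)cn1)C1CCCN(C(=O)c2cc(C(F)(F)F)cc(C(F)(F)F)c2)C1`. It differs from compound 3 in the whole amide substituent: 5-chloropyridin-2-yl in place of 3-(allyloxy)phenyl on an amide-type nitrogen. Among the compounds with values here, no measured step exchanges this ring itself; the three steps recorded all vary a group on a carbon ring that is kept in place. The only element that has so far lifted inhibition, the (pyrrolidin-1-yl)methyl of compound 2, is absent from compound 4, so the nearest guides are compound 1 and compound 3, both at no inhibition. On that basis no step beyond the scatter is expected for compound 4, with a number 5 percentage points higher from compound 3 to compound 4 (within the scatter) as the estimated movement from compound 3. For compound 4 the expected value in this assay is 5%, within an estimated range of 0% to 25%.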

Compound 4, a percentage reported as inhibition, at one concentration (the size of the read-out at that concentration, not a potency): 0%
For compound 4 the middle estimate is 5 percentage points above the measured one; the range from low to high includes it.
By their numbers in this assay, from the lowest: compounds 1, 3 and 4 (each within the scatter of the next); then compound 2.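

Replacing the whole amide substituent with 5-chloropyridin-2-yl, a six-membered aromatic ring with 1 hetero atom in place of one of carbon only, gives no change at the digits printed from compound 3 to compound 4 (within the scatter) in this assay and no change at the digits printed from compound 1 to compound 4 (within the scatter) on the same read-out, so a change of the ring itself on the amide-type nitrogen, and not only of a group on a retained carbon ring, leaves the number where it was. The step of a number 51 percentage points lower from compound 2 to compound 4 (beyond the scatter) in this assay shows that, of the amide substituents shown, 3-((pyrrolidin-1-yl)methyl)phenyl alone stands beyond the scatter of the others, now against two different ring types. No supporting data bear on why these levels arise.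

Still open, on these data alone, is whether a (pyrrolidin-1-yl)methyl group carried on the 5-chloropyridin-2-yl ring would give the same lift as on the carbon ring of compound 2. As far as these compounds go, it is equally open whether that lift belongs to the pyrrolidine specifically or would also appear with a morpholine, a primary amine on the same methyl link, or a carboxylic acid at that place.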